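A few compounds are considered here, and "the series" means these few. Any claim that something is new, unique, unknown or untested is made for them only; others in the source may bear on it.

Two compounds share one core and carry a urea tail on it. Compound 1 `COc1cc(Cl)cc(-c2nn(-c3cccc(NC(=O)Nc4cccc(C(F)(F)F)c4)c3)cc2-c2ccncc2)c1` bears a methoxy on its chloro-substituted ring and a trifluoromethyl group on the far end of the urea. In a functional assay on OVCAR-8 cells (Homo sapiens) for inhibition, read by sulforhodamine B assay, with a stated time of 48 h, tested at 1 uM (on this read-out higher numbers stand for a weaker effect at the one concentration tested and lower numbers for a stronger effect), compound 1 gives 54%. Compound 2 `O=C(Nc1cccc(-n2cc(-c3ccncc3)c(-c3cc(O)cc(Cl)c3)n2)c1)Nc1ccc(Cl)c(Cl)c1` carries instead a hydroxy on that ring and two chlorines on the urea's far ring; in this assay compound 2 gives 56%. These two numbers lie within the scatter of each other, so neither compound can be told apart from the other on this read-out.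

Compound 3 `COc1cc(Cl)cc(-c2nn(-c3cccc(NC(=O)Nc4ccc(Cl)c(Cl)c4)c3)cc2-c2ccncc2)c1` is compound 2 with one change: methyl in place of hydrogen on an oxygen on an aromatic ring. Compound 1 already carries that same methoxy, and its value 54% sits close to that of compound 2, so the step expected from compound 2 to compound 3 is a number 1 percentage points lower from compound 2 to compound 3 (within the scatter), none beyond the scatter. Compound 3 is therefore estimated at 55%, with a likely range from 42% to 68%.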

Compound 3, a percentage reported as activity, at one concentration (the size of the read-out at that concentration, not a potency): 78%
Compound 3: middle estimate off by 23 percentage points, on the low side; measured number outside the range, above it.
By their numbers in this assay, from the lowest: compounds 1 and 2 (each within the scatter of the next); then compound 3.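

In this assay, a methyl on the oxygen of the aromatic ring, which turns hydroxy into methoxy, weakens the effect (a number 22 percentage points higher from compound 2 to compound 3 (beyond the scatter)). With that methoxy kept, 3,4-dichlorophenyl in place of 3-(trifluoromethyl)phenyl on the amide-type nitrogen also weakens it (a number 24 percentage points higher from compound 1 to compound 3 (beyond the scatter)). The close values of compound 1 and compound 2 therefore concealed two single changes that each matter, so neither the oxygen substituent nor the far end of the urea can be treated as a silent spot in these pairs.

The compounds shown leave open how an ethoxy or an amine would behave at this position on the aromatic ring, and whether hydroxy to methoxy gives a similar step when the far ring is 3-(trifluoromethyl)phenyl. No measurement here accounts for either step.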